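This account rests on a few compounds, and the source may have more. Where it says the series, first, only, none or still open, it means among the compounds named here.

Measured in an assay on RMS13 cells for displacement of a labelled ligand from Urotensin-2 receptor (Homo sapiens), read by scintillation proximity assay; on this read-out lower numbers stand for stronger inhibition and higher numbers for weaker inhibition:
compound 1 `CCN1CCN(c2cccc3c2CN([C@H](CCCNC(=O)c2cccs2)c2ccc(OC)c(OC)c2)C3=O)CC1`: 18 nM
compound 2 `COc1ccc([C@@H](CCCN(C)S(=O)(=O)c2cccs2)N2Cc3c(cccc3N3CCN(C4CCC4)CC3)C2=O)cc1OC`: 44 nM
compound 3 `COc1ccc([C@@H](CCCN(C)S(=O)(=O)c2cccs2)N2Cc3c(cccc3N3CCN(C)CC3)C2=O)cc1OC`: < 6 nM

Compound 3 gives only a limit, < 6 nM, and no number; (the limit of < 6 nM in this assay, at which 1 of the 3 values shown sits). The next compound in the series is compound 4 `COc1ccc([C@@H](CCCN(C)S(=O)(=O)c2cccs2)N2Cc3c(cccc3N3CCN(C4CC4)CC3)C2=O)cc1OC`. It differs from compound 3 in one place: cyclopropyl in place of methyl on an amine nitrogen in a ring. Among the compounds with values here, the only measured step that bears on this change is the one on the same ring nitrogen, an at least 7.3-fold lower number from compound 2 to compound 3 (0.86 log units; beyond the scatter), where cyclobutyl gave the higher number and methyl the lower. Cyclopropyl is the ring one carbon smaller than cyclobutyl, so a number above that of compound 3 but not as high as that of compound 2 seems the most natural expectation, though the limit on compound 3 leaves the size of the step open. Compound 4 is therefore estimated at 15 nM in this assay, with a range of 5 nM to 45 nM. Against compound 3 this amounts to an expected step of an at least 2.5-fold higher number from compound 3 to compound 4 (0.39 log units; beyond the scatter).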

Compound 4, inhibition constant: 59 nM
Beside the measured number, compound 4's estimate is 3.9-fold (0.59 log units) below it; measured number above the stated range.
By their numbers in this assay, from the lowest: compound 1; then compounds 2 and 4 (each within the scatter of the next). At a limit, below all of these: compound 3.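

In this assay, 4-cyclopropylpiperazin-1-yl in place of 4-methylpiperazin-1-yl gives an at least 9.8-fold higher number from compound 3 to compound 4 (0.99 log units; beyond the scatter), so the rise seen with cyclobutyl on this amine nitrogen in a ring also appears with the smaller cyclopropyl ring. The two rings are not told apart at this position, with a 1.3-fold higher number from compound 2 to compound 4 (0.13 log units; within the scatter). Compound 3 remains a limit and not a number: the limit of < 6 nM in this assay, at which 1 of the 4 values shown sits.

Still open, going by these compounds, is how the number changes between methyl and cyclopropyl on this nitrogen, which ethyl or isopropyl on the otherwise unchanged structure of compound 3 would address. On these data alone, compound 1 carries ethyl there but also differs in another place, so it does not settle the question, and the effect of a bare amine hydrogen on this nitrogen also remains open.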